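Aryl sulfonyl variation on the shared piperidine core

The compounds below may be only part of what the source reports. "The series", "measured", "known", "first", "only" and "open" are said of these compounds alone.

Measured in a functional assay on DLD-1 cells (Homo sapiens) for antiproliferative activity, read by CellTiter-Glo, with a stated time of 72 h; a higher number here means a weaker inhibitor, a lower number a stronger inhibitor:
compound 1 `Cc1nc(Cl)sc1S(=O)(=O)N1CCC(N2CCC(C)CC2)CC1` — 1.6 nM
compound 2 `CC1CCN(C2CCN(S(=O)(=O)c3cccc(Br)c3)CC2)CC1` — 3.2 nM
compound 3 `CC1CCN(C2CCN(S(=O)(=O)c3ccc(F)cc3F)CC2)CC1` — 102 nM

Compound 2 stands second highest of the three numbers; a 2.0-fold higher number from compound 1 to compound 2 (0.30 log units; within the scatter), whereas a 32-fold higher number from compound 2 to compound 3 (1.50 log units; beyond the scatter) and a 64-fold higher number from compound 1 to compound 3 (1.80 log units; beyond the scatter). Compound 4 `COc1ccc(Br)cc1S(=O)(=O)N1CCC(N2CCC(C)CC2)CC1` differs from compound 2 by methoxy in place of hydrogen on an aromatic carbon. Among the measured compounds shown here, no measured step adds a single group to an otherwise fixed phenyl ring; the steps to compound 3 show only that a different substitution pattern on the phenyl ring can shift this assay by a large amount, in either direction unknown. The step from compound 2 to compound 4 is therefore expected to be modest, leaning toward a higher number, with wide uncertainty: a 2.5-fold higher number from compound 2 to compound 4 (0.40 log units; beyond the scatter). For compound 4 the estimate in this assay is 8 nM, range 2 nM to 40 nM.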

Compound 4, half-maximal inhibitory concentration: 2 nM
For compound 4 the middle estimate is 4.0-fold (0.60 log units) above the measured one, within the range that was stated.
By their numbers in this assay, from the lowest: compounds 1, 4 and 2 (each within the scatter of the next); then compound 3.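

In this assay, methoxy in place of hydrogen on an aromatic carbon, ortho to a large group and para to a bromo group, gives a 1.6-fold lower number from compound 2 to compound 4 (0.20 log units; within the scatter). Among the compounds shown here, this is the first step that adds a single group to an otherwise fixed phenyl ring, and this position accepts methoxy without a change beyond the scatter. No measurement on the series bears on the reason for this result.

From the compounds shown here alone, whether an amine, a carboxylic acid or a longer chain at this carbon would give a similar number remains open. Also open, going by these compounds, is whether methoxy would behave the same way on the 2,4-difluorophenyl ring of compound 3.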